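This account rests on a few compounds, and the source may have more. Where it says the series, first, only, none or still open, it means among the compounds named here.

Measured compounds:
compound 1 `CCCCNc1nc(N)nc2c1CCN(Cc1ccccc1)C2`: 0.4 uM
compound 2 `CCCCNc1nc(N)nc2c1CCN(C(=O)c1ccccc1)C2`: 0.8 uM

For the measured compounds named here, in an assay on HEK293 cells for agonist activity at Toll-like receptor 8 (Homo sapiens), read by a luciferase reporter, with a stated time of 6 h (on this read-out lower numbers stand for an effect already at smaller amounts and higher numbers for an effect only at larger amounts of compound), compound 2 holds the higher of the two numbers; the only measured neighbour lies at a 2.0-fold higher number from compound 1 to compound 2 (0.30 log units; within the scatter). Compound 3 `CCCCNc1nc(N)nc2c1CCN(S(C)(=O)=O)C2` differs from compound 2 by methylsulfonyl in place of benzoyl on an amine nitrogen in a ring. Going by the values given here, the one step that bears on it is the earlier exchange on the same amine nitrogen, a 2.0-fold higher number from compound 1 to compound 2 (0.30 log units; within the scatter), which stayed within the scatter. Among the compounds with values here, no measured step brings in methylsulfonyl or removes the aromatic ring, so the expectation rests on thin ground: a modest rise in the number, a 1.9-fold higher number from compound 2 to compound 3 (0.27 log units; within the scatter), is expected. Compound 3 is estimated at 1.5 uM, within 0.4 uM to 6 uM.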

Compound 3, minimum effective concentration: 0.8 uM
For compound 3 the middle estimate is 1.9-fold (0.27 log units) above the measured one, within the range that was stated.
By their numbers in this assay, from the lowest: compounds 1, 2 and 3 (each within the scatter of the next).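

In this assay, the amine nitrogen in a ring carries three quite different groups with no step beyond the scatter: methylsulfonyl in place of benzoyl gives (no change at the digits printed from compound 2 to compound 3 (within the scatter)), and methylsulfonyl in place of benzyl gives (a 2.0-fold higher number from compound 1 to compound 3 (0.30 log units; within the scatter)). An aromatic ring on this nitrogen is therefore not required for a reading in this range, which the two earlier compounds could not show. No available evidence bears on the reason for this.

The compounds shown leave open whether the free ring amine, an acetyl group or a longer alkyl chain on this nitrogen would stay in the same range. They also leave open whether a carboxylic acid here would do so.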